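This account rests on a few compounds, and the source may have more. Where it says the series, first, only, none or still open, it means among the compounds named here.

For the measured compounds named here, in an assay on cells for inhibition of Palmitoleoyl-protein carboxylesterase NOTUM variant C330S (Homo sapiens), read by fluorescence, with a stated time of 40 min (a lower number here means a stronger inhibitor, a higher number a weaker inhibitor), compound 2 `O=C(O)C1CCN(c2cccc(C(F)(F)F)c2)C1` gives 11000 nM, the lowest of the two numbers so far. Compound 1 `O=C(O)C1CCN(c2ccccc2)C1` gives 48000 nM in this assay, and between them there was a 4.4-fold lower number from compound 1 to compound 2 (0.64 log units; beyond the scatter). Compound 3 `O=C(O)C1CCN(c2cccc(OC(F)(F)F)c2)C1` differs from compound 2 by trifluoromethoxy in place of trifluoromethyl on an aromatic carbon. Going by the values given here, no measured step exchanges one fluorine-bearing group for another, and the single step in hand, hydrogen to trifluoromethyl, was itself only modest. For compound 3 the step of a 1.4-fold lower number from compound 2 to compound 3 (0.14 log units; within the scatter) is therefore expected to stay within the scatter. The estimate for compound 3 in this assay is 8000 nM, with a range from 3000 nM to 25000 nM.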

Compound 3, half-maximal inhibitory concentration: 63000 nM
For compound 3 the middle estimate is 7.9-fold (0.90 log units) below the measured one; measured number above the stated range.
By their numbers in this assay, from the lowest: compound 2; then compounds 1 and 3 (each within the scatter of the next).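

In this assay this place on the aromatic ring proves sensitive to which fluorine-bearing group it carries: trifluoromethoxy in place of trifluoromethyl gives a 5.7-fold higher number from compound 2 to compound 3 (0.76 log units; beyond the scatter) and so does not keep what trifluoromethyl gained. Set against hydrogen, trifluoromethoxy gives a 1.3-fold higher number from compound 1 to compound 3 (0.12 log units; within the scatter) and thus no separation from the core of compound 1. No evidence at hand explains what the change does. Going by these compounds, whether a methyl, a chlorine, a nitrile or an amine at this place would track trifluoromethyl or trifluoromethoxy remains open, as does how either group reads on another ring carbon.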